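This account rests on a few compounds, and the source may have more. Where it says the series, first, only, none or still open, it means among the compounds named here.

The three measured compounds share one core. Compound 1 `OCCOCn1c(Cl)nc2cc(Cl)c(Cl)cc21` is tested in a functional assay on KB cells (Homo sapiens) for inhibition; a lower number here means a stronger inhibitor, a higher number a weaker inhibitor. In this assay compound 1 gives > 320000 nM, which is a limit of the assay rather than a number. Compound 2 `OCCOCn1c(SCc2ccccc2)nc2c(Cl)cc(Cl)cc21` gives in this assay > 100000 nM, again a limit. Compound 3 `Nc1nc2c(Cl)c(Cl)ccc2n1COCCO` gives in this assay > 100000 nM, also a limit. Compound 1 therefore cannot be ranked against the others: its own result sits at the limit of > 320000 nM in this assay, at which 1 of the 3 values shown sits, while the other two sit at the limit of > 100000 nM in this assay, at which 2 of the 3 values shown sit. Going by the values given here, no pair of measured compounds differs in only one place, so no measured step can guide the next change.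

Compound 4 `OCCOCn1c(S)nc2cc(Cl)c(Cl)cc21` differs from compound 1 by sulfanyl in place of chloro on an aromatic carbon, in words sulfanyl in place of chloro on an aromatic carbon. Among the compounds with values here, compound 1 reaches only a limit in this assay, so no step of definite size can be measured from it. The step is expected to be none beyond the scatter, with compound 4 likely staying at or beyond a limit: an at least 1.6-fold lower number from compound 1 to compound 4 (0.20 log units; that floor lies within the scatter). The estimate for compound 4 in this assay is 200000 nM, with an expected range from 50000 nM to 1000000 nM, and a high chance that only a limit is reported.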

Compound 4, half-maximal inhibitory concentration: > 100000 nM
Compound 4: a limit, no number; the forecaster's own chance of this, stated with the estimate: 85%; the middle value lies beyond the limit too.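

In this assay compound 4 gives > 100000 nM, which is a limit of the assay and not a number. Compound 1 also stands at a limit, and no step can be read between compound 1 and compound 4. The compounds shown leave open whether any group on the shared core gives a definite number in this assay.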